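Chloro in place of cyclopropyl on the amide compound

The source may hold more compounds than are shown below. What is called first, only, known or untested is meant among the compounds shown, and "the series" means these compounds.

In an ADME assay on microsomes from liver (Homo sapiens) for metabolic stability, read by LC-MS, using NADPH, with a stated time of 30 min, tested at 1 uM (on this read-out lower numbers stand for slow clearance and higher numbers for fast clearance), compound 1 `CC#Cc1cncc(-c2ccc3c(c2)[C@@]2(COC(N)=N2)c2cc(-c4ccnc(F)c4)ncc2O3)c1` gives 40 mL.min-1.g-1 and compound 2 `NC1=N[C@@]2(CO1)c1cc(-c3cncc(C#CCO)c3)ccc1Oc1cnc(C3=CCOCC3)cc12` gives 84 mL.min-1.g-1. Compound 3 `NC1=N[C@@]2(CO1)c1cc(NC(=O)c3ccc(Cl)cn3)ccc1Oc1cnc(C3CC3)cc12` gives < 14 mL.min-1.g-1, which is a limit of the assay and not a number. Compound 3 thus stands at the limit of < 14 mL.min-1.g-1 in this assay, at which 1 of the 3 values shown sits, the only one of the three measured compounds to do so.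

Compound 4 `NC1=N[C@@]2(CO1)c1cc(NC(=O)c3ccc(Cl)cn3)ccc1Oc1cnc(Cl)cc12` keeps the structure of compound 3 except at one place, next to the ring nitrogen (chloro in place of cyclopropyl on an aromatic carbon). On these data alone, its value in this assay is still open.

Going by the values given here, no measured pair differs in one place only, so no step can be read directly for this change. Compound 1 and compound 2 differ from compound 3 in several places and give no measure of this single change. A small step is expected, at most a slight rise and probably not beyond the usual scatter, and the limit on compound 3 leaves its true size open. The expected step is an at least 1.0-fold higher number from compound 3 to compound 4 (0.02 log units; that floor lies within the scatter). For compound 4 the estimated value is 15 mL.min-1.g-1, with an expected range of 8 mL.min-1.g-1 to 35 mL.min-1.g-1.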

Compound 4, intrinsic clearance in microsomes: 37 mL.min-1.g-1
Beside the measured number, compound 4's estimate is 2.5-fold (0.39 log units) below it; the whole stated range lies below it.
By their numbers in this assay, from the lowest: compounds 4 and 1 (each within the scatter of the next); then compound 2. At a limit, below all of these: compound 3.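

This position, on an aromatic carbon next to the ring nitrogen, now has a single change that can be read directly: chloro in place of cyclopropyl gives an at least 2.6-fold higher number from compound 3 to compound 4 (0.42 log units; beyond the scatter) in this assay. The position is therefore not indifferent to this exchange, something compound 1 and compound 2 could not show, since each differs from compound 3 in several places. Compound 3 sits at a limit of the assay, so the step is known only as a lower bound and its true size stays open: the limit of < 14 mL.min-1.g-1 in this assay, at which 1 of the 4 values shown sits.

One pair cannot separate the loss of the cyclopropyl ring from the entry of chloro, and it assigns no property to either group. On these data alone, how an amine, a methoxy group or a nitrile at this position would stand in this assay remains open, as does whether the step carries over to compounds that share the other features of compound 1 or compound 2.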